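Swapping an Ether Chain for a Cyclic Amide Arm

This account rests on a few compounds, and the source may have more. Where it says the series, first, only, none or still open, it means among the compounds named here.

Three compounds sharing a thiazole-bearing core have been checked in an ADME assay on HepG2 2.2.15 cells (Homo sapiens) for cytotoxicity; on this read-out higher numbers stand for lower toxicity in this test and lower numbers for higher toxicity in this test. Compound 1 `Cc1ccc(C(=O)Nc2ncc(Cc3ccc(F)cc3)s2)cc1` gives "not toxic" (no number reported). Compound 2 `CC(C)(C)OC(=O)Nc1ncc(C(Oc2ccc(Cc3ccccc3)cc2)c2ccc(Cl)cc2)s1` gives > 50000 nM, which is a limit of the assay rather than a number. Compound 3 `COCCNc1ncc(C(Oc2ccc3cc(Br)ccc3c2)c2ccc(Cl)cc2)s1` gives "not toxic" (no number reported). Compound 3 therefore stands without a single number in this assay; the only numerical anchor among its neighbours is the limit of > 50000 nM in this assay, at which 1 of the 3 values shown sits, and the remaining entry carries no number at all.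

Compound 4 `O=C(Nc1ncc(C(Oc2ccc3cc(Br)ccc3c2)c2ccc(Cl)cc2)s1)C1CCCO1` differs from compound 3 in one place: (oxolan-2-yl)carbonyl in place of 2-methoxyethyl on a nitrogen on an aromatic ring. Among the compounds with values here, since no step between measured compounds exists, the size of this change in this assay can only be anticipated, and the expectation is for no shift beyond the usual scatter, with the read-out most likely ending again at a limit rather than a number. Compound 4 is expected to give about 50000 nM, estimated between 20000 nM and 100000 nM.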

Compound 4, half-maximal cytotoxic concentration: "not toxic" (no number reported)
Compound 4: no number reported; there is nothing to compare the estimate with.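

In this assay, within the data shown here, compound 3 and compound 4 are both reported only as not toxic, without a number, so no step between them can be read. The compounds shown leave open whether (oxolan-2-yl)carbonyl in place of 2-methoxyethyl changes the half-maximal cytotoxic concentration at all.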